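This account rests on a few compounds, and the source may have more. Where it says the series, first, only, none or still open, it means among the compounds named here.

Measured compounds in the series:

compound 1, `Nc1ccccc1NC(=O)c1ccc(CSc2nccc(C(F)(F)F)n2)cc1`, in a functional assay on A-375 cells (Homo sapiens) for antiproliferative activity, read by CCK-8 assay, with a stated time of 72 h; a lower number here means a stronger inhibitor, a higher number a weaker inhibitor: 1550 nM
compound 2, `Nc1ccccc1NC(=O)/C=C/c1ccc(CSc2ccc(F)cc2)cc1`, in this assay: 3670 nM
compound 3, `Nc1ccccc1NC(=O)c1ccc(CSc2cccc(F)c2)cc1`, in this assay: 3900 nM

Compound 2 stands second highest of the three numbers. Compound 3 sits within the scatter of compound 2, so the two are not ordered. Compound 1 gives a lower number than compound 2, and that gap is beyond the scatter.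

Compound 4, `CC(C)(C)c1ccc(SCc2ccc(/C=C/C(=O)Nc3ccccc3N)cc2)cc1`, has not been measured. It differs from compound 2 by tert-butyl in place of fluoro on an aromatic carbon. Within the data shown here, no measured pair shows this same change, so no step size is known for it. The expectation is a small step in this assay, if any, with a slightly lower number for compound 4 than for compound 2, but not clearly beyond the scatter. The expected step from compound 2 to compound 4 is a 1.5-fold lower number from compound 2 to compound 4 (0.17 log units; within the scatter). Compound 4 is estimated at 2500 nM, in the range 800 nM to 8000 nM.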

Compound 4, half-maximal inhibitory concentration: 1550 nM
For compound 4 the middle estimate is 1.6-fold (0.21 log units) above the measured one, and the stated range covers the measured number.
By their numbers in this assay, from the lowest: compounds 1 and 4 (each within the scatter of the next); then compounds 2 and 3 (each within the scatter of the next).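

In this assay, among these compounds, the change from 4-fluorophenyl to 4-(tert-butyl)phenyl gives a 2.4-fold lower number from compound 2 to compound 4 (0.37 log units; beyond the scatter) and is the first single-place step. This position, on an aromatic carbon para to a large group, therefore tolerates tert-butyl with its 4 heavy atoms in place of fluoro, and the number falls rather than rises. Nothing measured here accounts for the step.

Open, from the compounds shown here alone, is how a methyl or an amine at this same position would read, and whether tert-butyl would give a similar step on the core of compound 3.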